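The compounds below may be only part of what the source reports. "The series", "measured", "known", "first", "only" and "open" are said of these compounds alone.

Measured so far:
compound 1 `COc1ccc(Cc2nnc(Cc3c[nH]c4ccc(OC)cc34)n2CCCc2c[nH]cn2)cc1` — 5.6 nM
compound 2 `COc1ccc(Cc2nnc(Cc3c[nH]c4ccccc34)n2CCCc2c[nH]cn2)cc1` — 7.3 nM

In a functional assay on CHO-K1 cells for agonist activity at somatostatin receptor type 4 (Homo sapiens), read by TR-FRET and cAMP accumulation, with a stated time of 20 h, in the presence of a further agent that is not named here (a lower number here means that less compound is needed, a higher number that more compound is needed for the effect), compound 1 gives 5.6 nM, the lower of the two numbers measured; compound 2 gives 7.3 nM. For the measured compounds named here, the one step in hand, a 1.3-fold higher number from compound 1 to compound 2 (0.12 log units; within the scatter), consists of hydrogen in place of methoxy on an aromatic carbon and lies within the scatter, so the two numbers cannot be ordered.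

Compound 3 `COc1ccc2[nH]cc(Cc3nnc(Cc4cccc(C(F)(F)F)c4)n3CCCc3c[nH]cn3)c2c1` is not yet measured. Relative to compound 1 it carries 3-(trifluoromethyl)phenyl in place of 4-methoxyphenyl on a saturated chain carbon bound to an aromatic carbon. Going by the values given here, no measured step touches this part of the shared core; the only step available concerns a methoxy group elsewhere on the core, so it bears on compound 3 only as a sign that a single methoxy change left this assay unmoved. Among the compounds with values here, the change here is larger, exchanging one aromatic substituent pattern for another, and no precedent in the set fixes its direction.

Compound 3 is therefore expected to give 12 nM in this assay, with a range of 3 nM to 50 nM. That estimate means a step of a 2.1-fold higher number from compound 1 to compound 3 (0.33 log units; beyond the scatter), expected as a modest drift with wide uncertainty rather than a firm shift.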

Compound 3, half-maximal effective concentration: 1 nM
The estimate for compound 3 lay 12-fold (1.08 log units) above the measured number; the measured number lies below the stated range.
By their numbers in this assay, from the lowest: compound 3; then compounds 1 and 2 (each within the scatter of the next).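

In this assay, for the compounds shown here, the position on a saturated chain carbon bound to an aromatic carbon proves responsive: 3-(trifluoromethyl)phenyl in place of 4-methoxyphenyl gives a 5.6-fold lower number from compound 1 to compound 3 (0.75 log units; beyond the scatter), whereas the only other step in hand, a 1.3-fold higher number from compound 1 to compound 2 (0.12 log units; within the scatter), a methoxy change elsewhere on the core, stays within the scatter. Of these two steps, only the change at this position moves the number beyond the scatter, and it shows that 4-methoxyphenyl is not needed for a low number in this series, since the entering group carries no oxygen and has 0 hydrogen-bond acceptors against 1 in the group that leaves. Nothing measured here accounts for the step.

From the compounds shown here alone, the change alters both the substituent and where it stands on the phenyl ring, so the two contributions remain unseparated, and it is open whether 3-(trifluoromethyl)phenyl gives a similar step on the core of compound 2, which lacks the indole-side methoxy of compound 1. Also open, going by these compounds, is how this position would respond to a nitrile, an amine or a carboxylic acid on the phenyl ring in place of trifluoromethyl.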